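The compounds below may be only part of what the source reports. "The series", "measured", "known", "first", "only" and "open" are said of these compounds alone.

In a functional assay on the whole organism with Mus musculus as the target (a lower number here means that less compound is needed, a higher number that more compound is needed for the effect), compound 1 `OC1CCN(c2ccc(-c3ccccc3F)nn2)CC1` gives 30 mg/kg. Compound 2 `O=[N+]([O-])c1ccc(-c2ccc(N3CCC(O)CC3)nn2)cc1`, which shares the core of the first, gives 54 mg/kg. Among the measured compounds shown here, these two numbers lie within the usual scatter of each other, so compound 1 stands level with the only other compound measured so far, and neither can be ranked above the other.

Compound 3 `Cc1ccccc1-c1ccc(N2CCC(O)CC2)nn1` has not been measured yet. It differs from compound 1 in a single place: methyl in place of fluoro on an aromatic carbon. In words, this is methyl in place of fluoro on an aromatic carbon, ortho to a large group. For the measured compounds named here, no measured pair shows what this kind of swap does, so no step beyond the scatter is expected in this assay, in either direction. The estimated change is small: a 1.2-fold higher number from compound 1 to compound 3 (0.07 log units; within the scatter). For compound 3 the expected value is 35 mg/kg, with an estimated range from 15 mg/kg to 80 mg/kg.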

Compound 3, dose for half-maximal effect: 40 mg/kg
For compound 3 the middle estimate is 1.1-fold (0.06 log units) below the measured one; low and high end bracket the measured number.
By their numbers in this assay, from the lowest: compounds 1, 3 and 2 (each within the scatter of the next).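

In this assay, among the compounds shown here, the swap of fluoro for methyl on an aromatic carbon, ortho to a large group, is the first one-place change that can be read: it is a 1.3-fold higher number from compound 1 to compound 3 (0.12 log units; within the scatter) and so stays within the scatter. At this position, then, the two groups cannot be told apart by the dose needed for the effect, and either one is compatible with activity in the whole animal. Nothing measured here explains this result, and a single pair cannot show a general rule.

From the compounds shown here alone, what a methoxy group, an amine or a carboxylic acid would do at this same position remains open. Also open, going by these compounds, is whether other places on the shared core would respond just as little to a change of one group.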